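The source may hold more compounds than are shown below. What is called first, only, known or untested is meant among the compounds shown, and "the series" means these compounds.

Measured so far in a functional assay on NCI-H460 cells (Homo sapiens) for inhibition, read by sulforhodamine B assay, with a stated time of 48 h; a lower number here means that less compound is tolerated, a higher number that more compound is tolerated:
Compound 1 `Nc1cc(N)c2nc(-c3ccccc3)c(Oc3ccc(Cl)c(Cl)c3)nc2c1` gives only a limit, < 100000 nM.
Compound 2 `CCOC(=O)[C@H](CCC(=O)O)NC(=O)c1ccc(Oc2nc3cc(N)cc(N)c3nc2-c2ccccc2)cc1` likewise gives only a limit, < 100000 nM.
Compound 3 `CCOC(=O)[C@H](CCC(=O)O)NC(=O)c1ccc(CNc2nc3cc(N)cc(N)c3nc2-c2ccccc2)cc1` also gives only a limit, < 100000 nM.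

Going by the values given here, compound 1 therefore stands at the limit of < 100000 nM in this assay, at which 3 of the 3 values shown sit; no number separates it from the other two, and no step between measured compounds can be drawn. Compound 4 `COc1ccc(Sc2nc3cc(N)cc(N)c3nc2-c2ccccc2)cc1` differs from compound 1 by (4-methoxyphenyl)sulfanyl in place of 3,4-dichlorophenoxy on an aromatic carbon. With the shared core untouched, the change in this assay from compound 1 to compound 4 is expected to be none beyond the scatter, a step that the limit leaves unreadable from compound 1 to compound 4, and compound 4 is expected to come back at a limit once more. The estimate for compound 4 in this assay is 30000 nM, with a range from 5000 nM to 100000 nM.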

Compound 4, concentration lethal to 50% of the cells: < 100000 nM
Compound 4: a limit, no number; the forecaster's own chance of this, stated with the estimate: 70%; the middle value does not contradict the limit.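

Going by these compounds alone, compound 1 and compound 4 both return only limits in this assay, so no step between them can be read. The compounds shown leave open whether (4-methoxyphenyl)sulfanyl in place of 3,4-dichlorophenoxy changes the value at all, and how the compounds rank.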